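Swapping cyclopentyl for 2,6-difluorophenyl on the ring nitrogen

A few compounds are considered here, and "the series" means these few. Any claim that something is new, unique, unknown or untested is made for them only; others in the source may bear on it.

Compound 2 `Nc1scc(CN2CCN(C3CCCC3)CC2)c1C(=O)c1ccc(Cl)cc1` stands highest of the two numbers in an assay on CHO cells for displacement of a labelled ligand from adenosine receptor A3 (Homo sapiens), read by scintillation counting, with a stated time of 120 min, tested at 10 uM (on this read-out higher numbers stand for more inhibition at the one concentration tested (going by the name of the read-out) and lower numbers for less inhibition), giving 3%. Its nearest neighbour, compound 1 `COc1ccc(N2CCN(Cc3csc(N)c3C(=O)c3ccc(Cl)cc3)CC2)cc1`, gives 0% in this assay, a gap within the scatter. Going by the values given here, the one comparable exchange on this ring nitrogen, a number 3 percentage points higher from compound 1 to compound 2 (within the scatter), stayed within the scatter. Compound 3 `Nc1scc(CN2CCN(c3c(F)cccc3F)CC2)c1C(=O)c1ccc(Cl)cc1` differs from compound 2 by 2,6-difluorophenyl in place of cyclopentyl on an amine nitrogen in a ring. Among the compounds with values here, with that single small precedent as the only guide, compound 3 is expected to show a number 1 percentage points lower from compound 2 to compound 3 (within the scatter), a step not beyond the scatter. Compound 3 is estimated at 2%, ranging from -8% to 12%.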

Compound 3, a percentage reported as inhibition, at one concentration (the size of the read-out at that concentration, not a potency): 4%
Compound 3: middle estimate off by 2 percentage points, on the low side; the range from low to high includes it.
By their numbers in this assay, from the lowest: compounds 1, 2 and 3 (each within the scatter of the next).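

On the ring nitrogen, 2,6-difluorophenyl gives a number 1 percentage points higher from compound 2 to compound 3 (within the scatter) and a number 4 percentage points higher from compound 1 to compound 3 (within the scatter) in this assay. A third group, now with fluorine on its aromatic ring, therefore still cannot be told apart from cyclopentyl or 4-methoxyphenyl at this position. No evidence here explains why these exchanges leave the read-out unmoved. The compounds shown leave open whether a carboxylic acid, or a longer chain ending in an amine, on this ring nitrogen would shift the read-out beyond the scatter.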